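Ethoxy for fluoro on the amide aryl ring

The source may hold more compounds than are shown below. What is called first, only, known or untested is meant among the compounds shown, and "the series" means these compounds.

Compound 1 `COc1ccc2c(=O)c(/C=C/C(=O)Nc3ccccc3C)coc2c1`: 26900 nM
Compound 2 `COc1ccc2c(=O)c(/C=C/C(=O)Nc3ccc(F)cc3)coc2c1`: 33900 nM

Among the measured compounds shown here, in a functional assay on Huh-7 cells (Homo sapiens) for inhibition, read by MTT assay, with a stated time of 48 h (a higher number here means a weaker inhibitor, a lower number a stronger inhibitor), compound 2 gives 33900 nM, the higher of the two numbers measured so far, with compound 1 at 26900 nM as its only neighbour. For the measured compounds named here, the sole measured step, a 1.3-fold higher number from compound 1 to compound 2 (0.10 log units; within the scatter), changed the group on the amide-type nitrogen and stayed within the scatter. Compound 3 `CCOc1ccc(NC(=O)/C=C/c2coc3cc(OC)ccc3c2=O)cc1` differs from compound 2 by ethoxy in place of fluoro on an aromatic carbon. As that one step bears on this change and was small, no step beyond the scatter is expected. Compound 3 is therefore estimated at 30000 nM, within 12000 nM to 85000 nM. The expected step is a 1.1-fold lower number from compound 2 to compound 3 (0.05 log units; within the scatter).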

Compound 3, half-maximal inhibitory concentration: 3230 nM
The estimate for compound 3 lay 9.3-fold (0.97 log units) above the measured number; the measured number lies below the stated range.
By their numbers in this assay, from the lowest: compound 3; then compounds 1 and 2 (each within the scatter of the next).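

In this assay, this position on the amide aryl ring proves able to move the number well beyond the scatter, which the earlier step did not show: with ethoxy in place of fluoro there is a 10-fold lower number from compound 2 to compound 3 (1.02 log units; beyond the scatter). The change from 2-methylphenyl to 4-ethoxyphenyl points the same way, with an 8.3-fold lower number from compound 1 to compound 3 (0.92 log units; beyond the scatter). Nothing measured here accounts for the lower number. The compounds shown leave open whether the step follows the ether oxygen or the carbon chain of ethoxy. Methoxy, butoxy or ethyl in the same place would separate the two.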